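Methylamino in place of anilino: series notes

This account rests on a few compounds, and the source may have more. Where it says the series, first, only, none or still open, it means among the compounds named here.

Values in a functional assay on HL-60 cells (Homo sapiens) for cytotoxicity, read by MTT assay, with a stated time of 3 days; on this read-out lower numbers stand for stronger inhibition and higher numbers for weaker inhibition:
- compound 1 `N#Cc1c(Cl)nc(SCc2nc3ccccc3[nH]2)nc1-c1ccccc1`: 4.46 nM
- compound 2 `N#Cc1c(NN)nc(SCc2nc3ccccc3[nH]2)nc1-c1ccccc1`: 11.9 nM
- compound 3 `N#Cc1c(Nc2ccccc2)nc(SCc2nc3ccccc3[nH]2)nc1-c1ccccc1`: 4.46 nM

Within the data shown here, on the numbers so far, compound 3 sits at the low end of this small set: no change at the digits printed from compound 1 to compound 3 (within the scatter). Against the one higher number, the record shows a 2.7-fold lower number from compound 2 to compound 3 (0.43 log units; beyond the scatter).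

The next change gives compound 4 `CNc1nc(SCc2nc3ccccc3[nH]2)nc(-c2ccccc2)c1C#N`. The difference is methyl in place of phenyl on a nitrogen on an aromatic ring, or anilino to methylamino.

Among the measured compounds shown here, no methylamino analogue has been measured, so the closest evidence is compound 2, which carries amino on that nitrogen rather than phenyl, with a 2.7-fold lower number from compound 2 to compound 3 (0.43 log units; beyond the scatter). The chloro comparison, no change at the digits printed from compound 1 to compound 3 (within the scatter), shows that the anilino group is not required for a low number. Together these point to a modest step to a higher number in this assay, no larger than the one seen with compound 2, and possibly none beyond the scatter.

The expected step is a 1.8-fold higher number from compound 3 to compound 4 (0.25 log units; within the scatter). Compound 4 is estimated at 8 nM, with an expected range of 3 nM to 22 nM.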

Compound 4, half-maximal inhibitory concentration: 6.57 nM
Estimate against measurement, compound 4: 1.2-fold (0.09 log units) above; the range from low to high includes it.
By their numbers in this assay, from the lowest: compounds 1, 3, 4 and 2 (each within the scatter of the next, the first and the last beyond it).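

Taking phenyl off this nitrogen and putting methyl on it gives a 1.5-fold higher number from compound 3 to compound 4 (0.17 log units; within the scatter) in this assay and so removes the six-membered aromatic ring of carbon without moving the number beyond the scatter. A low number at this position therefore does not depend on that ring, at least among the listed compounds. The other two new comparisons, a 1.8-fold lower number from compound 2 to compound 4 (0.26 log units; within the scatter) and a 1.5-fold higher number from compound 1 to compound 4 (0.17 log units; within the scatter), also stay within the scatter, so methylamino cannot be ranked against either the chloro or the hydrazine-type substituent on this read-out, although compound 2 and compound 3 remain apart beyond it.

Still open, on these data alone, is how a longer chain such as n-butyl on this nitrogen, a dimethylamino group or a carboxylic acid on the chain would read here. Nothing available explains these numbers.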